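Cyano in Place of Bromo: an Untested Aromatic Substituent

The source may hold more compounds than are shown below. What is called first, only, known or untested is meant among the compounds shown, and "the series" means these compounds.

Measured so far:
compound 1, `CC(C(=O)NCc1ccc(C(C)(C)C)cc1)c1ccc(NS(C)(=O)=O)cc1`, 17.5 nM
compound 2, `CC(C(=O)NCc1ccc(C(C)(C)C)cc1)c1ccc(NS(C)(=O)=O)c(Br)c1`, 25 nM

Within the data shown here, in a functional assay on CHO cells for antagonist activity at transient receptor potential cation channel subfamily V member 1 (Rattus norvegicus), read by fluorescence, with a stated time of 1 h (a lower number here means a stronger inhibitor, a higher number a weaker inhibitor), compound 1 gives the lowest of the two numbers, but the only step to it, a 1.4-fold higher number from compound 1 to compound 2 (0.15 log units; within the scatter), lies within the scatter, so the two measured compounds cannot be told apart on these data.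

Compound 3, `CC(C(=O)NCc1ccc(C(C)(C)C)cc1)c1ccc(NS(C)(=O)=O)c(C#N)c1`, differs from compound 1 by cyano in place of hydrogen on an aromatic carbon. Among the measured compounds shown here, the one measured step that bears on this change is the step from compound 1 to compound 2, where a bromo entered the same place and the number moved by a 1.4-fold higher number from compound 1 to compound 2 (0.15 log units; within the scatter), within the scatter. For the measured compounds named here, no measured compound carries a cyano group, so the expectation rests on that single step alone. A small move, if any, is expected: the step from compound 1 to compound 3 is estimated at a 1.4-fold higher number from compound 1 to compound 3 (0.15 log units; within the scatter). Compound 3 is therefore expected to give about 25 nM in this assay, with a range from 10 nM to 65 nM.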

Compound 3, inhibition constant: 467 nM
Beside the measured number, compound 3's estimate is 19-fold (1.27 log units) below it, outside the stated range (above it).
By their numbers in this assay, from the lowest: compounds 1 and 2 (each within the scatter of the next); then compound 3.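

In this assay this place, ortho to a methanesulfonamido group, proves sensitive to what sits on it: cyano in place of hydrogen gives a 27-fold higher number from compound 1 to compound 3 (1.43 log units; beyond the scatter) and so separates compound 3 from compound 1, which the bromo of compound 2 did not do. Cyano in place of bromo on the same carbon gives a 19-fold higher number from compound 2 to compound 3 (1.27 log units; beyond the scatter), so the two substituents are not interchangeable here, and the earlier pair alone could not have shown this. Nothing given here accounts for the gap between cyano and bromo at this place.

The compounds shown leave open where a chloro, a methyl, a methoxy or an amine on this carbon would fall relative to bromo and cyano. They also leave open whether cyano would give a similar step on another carbon of the same ring.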